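Moving the Fluorine Around the Benzyl Ring

The compounds below may be only part of what the source reports. "The series", "measured", "known", "first", "only" and "open" are said of these compounds alone.

Measured so far:
compound 1 `C=C(Br)C(=O)Nc1ccc(/C=C2\SC(=O)N(C)C2=O)cc1` — 870 nM
compound 2 `C=C(Br)C(=O)Nc1ccc(/C=C2\SC(=O)N(Cc3ccc(F)cc3)C2=O)cc1` — 2000 nM

In a functional assay on HeLa cells (Homo sapiens) for cytotoxicity, read by cell counting, with a stated time of 4 days (on this read-out lower numbers stand for stronger inhibition and higher numbers for weaker inhibition), compound 1 gives 870 nM, while compound 2 gives 2000 nM. Among the measured compounds shown here, compound 2 thus carries the higher of the two numbers, and its only neighbour is compound 1, separated from it by a 2.3-fold higher number from compound 1 to compound 2 (0.36 log units; beyond the scatter). That step replaces hydrogen with a 4-fluorophenyl group on a saturated chain carbon bound to an amide-type nitrogen in a ring.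

Compound 3 `C=C(Br)C(=O)Nc1ccc(/C=C2\SC(=O)N(Cc3cccc(F)c3)C2=O)cc1` differs from compound 2 by 3-fluorophenyl in place of 4-fluorophenyl on a saturated chain carbon bound to an amide-type nitrogen in a ring. For the measured compounds named here, no measured pair bears on this change: the single step on record concerns adding the fluorinated ring, not shifting the fluorine within it. With nothing to point either way, the expected step from compound 2 to compound 3 is estimated to lie within the scatter, at no change at the digits printed from compound 2 to compound 3 (within the scatter). Compound 3 is therefore expected to give about 2000 nM, estimated between 800 nM and 5000 nM.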

Compound 3, half-maximal inhibitory concentration: 5900 nM
Beside the measured number, compound 3's estimate is 3.0-fold (0.47 log units) below it; the whole stated range lies below it.
By their numbers in this assay, from the lowest: compound 1; then compound 2; then compound 3.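

In this assay, the place of the fluorine on the benzyl ring matters in its own right: with the same atoms joined differently, going from 4-fluorobenzyl to 3-fluorobenzyl gives a 3.0-fold higher number from compound 2 to compound 3 (0.47 log units; beyond the scatter). The 3-fluorophenyl group also widens the distance from the starting compound, with a 6.8-fold higher number from compound 1 to compound 3 (0.83 log units; beyond the scatter), so both fluorinated groups at this position go with higher numbers than compound 1, and neither goes against that pattern. Nothing at hand accounts for the effect of moving the fluorine.

The compounds shown leave open whether a plain benzyl group, without fluorine, would stand closer to compound 1 or to the fluorinated pair. They also leave open how a chlorine or a methoxy group would behave at either ring position named here, and how a longer chain would compare.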